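The source may hold more compounds than are shown below. What is called first, only, known or untested is meant among the compounds shown, and "the series" means these compounds.

Measured compounds:
Compound 1 `CCc1cccc2c(OC)c(-c3occ(C)c3COC)ccc12` gives 9.7 ug/mL in a functional assay on MDA-MB-231 cells (Homo sapiens) for cytotoxicity, read by MTT assay, with a stated time of 72 h; on this read-out higher numbers stand for an effect only at larger amounts of compound and lower numbers for an effect already at smaller amounts.
Compound 2 `CCc1cccc2c(OC)c(-c3occ(C)c3CBr)ccc12` gives 4.6 ug/mL in this assay.
Compound 3 `CCc1cccc2c(OC)c(-c3occ(C)c3COCC(F)(F)F)ccc12` gives 5.3 ug/mL in this assay.

Compound 3 stands second highest of the three numbers; its nearest neighbour is compound 2 and its furthest is compound 1, and both gaps lie within the scatter. The shared core carries a saturated chain carbon bound to an aromatic carbon, and the three measured compounds differ only in what sits on that carbon. Of those steps, a 2.1-fold lower number from compound 1 to compound 2 (0.32 log units; beyond the scatter) is the only one beyond the scatter; a 1.8-fold lower number from compound 1 to compound 3 (0.26 log units; within the scatter) and a 1.2-fold higher number from compound 2 to compound 3 (0.06 log units; within the scatter) are within it.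

Compound 4 `CCc1cccc2c(OC)c(-c3occ(C)c3COC(=O)CCN(CC)CC)ccc12` is not yet measured. It differs from compound 3 as follows: (2-(diethylamino)ethyl)carbonyl in place of 2,2,2-trifluoroethyl on an oxygen on a saturated carbon. For the measured compounds named here, no measured step exchanges a 2,2,2-trifluoroethyl for a (2-(diethylamino)ethyl)carbonyl at this oxygen, so nothing directly bears on the change; the three measured steps at this part of the molecule were all small. Compound 4 is therefore expected to stay close to compound 3, with a 1.2-fold higher number from compound 3 to compound 4 (0.09 log units; within the scatter) not expected to go beyond the scatter, though the wider range is held open for a change of this size. The estimate for compound 4 is 6.5 ug/mL, between 2.5 ug/mL and 17 ug/mL.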

Compound 4, concentration for half-maximal effect: 1.7 ug/mL
The estimate for compound 4 lay 3.8-fold (0.58 log units) above the measured number; the whole stated range lies above it.
By their numbers in this assay, from the lowest: compound 4; then compounds 2, 3 and 1 (each within the scatter of the next, the first and the last beyond it).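

Compound 4 shows that this position can carry more than the small shifts seen so far: with (2-(diethylamino)ethyl)carbonyl on the oxygen, this assay gives a 3.1-fold lower number from compound 3 to compound 4 (0.49 log units; beyond the scatter) and a 2.7-fold lower number from compound 2 to compound 4 (0.43 log units; beyond the scatter) and also a 5.7-fold lower number from compound 1 to compound 4 (0.76 log units; beyond the scatter) as its steps. For the compounds shown here, all three lie beyond the scatter, so compound 4 has the lowest number of the four, whereas the earlier compounds had only one step beyond it. Nothing available explains this drop.

As far as these compounds go, it remains open whether the change depends on the carbonyl, the diethylamino nitrogen or both. An acetyl group on the same oxygen and a 2-(diethylamino)ethyl chain without the carbonyl would separate these two parts, and a longer chain between carbonyl and amine would test the spacing.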